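Sulfonamide aryl variation on a shared benzoxazole-free core note

A few compounds are considered here, and "the series" means these few. Any claim that something is new, unique, unknown or untested is made for them only; others in the source may bear on it.

The series keeps the core of compound 1 `Cc1ccccc1S(=O)(=O)Nc1ccc2oc(-c3ccccc3)nc2c1` and varies the aryl group on the sulfonyl sulfur. In an assay on isolated protein for inhibition of malate dehydrogenase, mitochondrial (Sus scrofa), with stated times of 45 min and 30 min (a lower number here means a stronger inhibitor, a higher number a weaker inhibitor), compound 1 gives only a limit, > 63000 nM. Compound 2 `O=S(=O)(Nc1ccc2oc(-c3ccccc3)nc2c1)c1cccc(F)c1` carries 3-fluorophenyl in place of 2-methylphenyl on the sulfonyl sulfur; in this assay compound 2 likewise gives a limit, > 63000 nM. Compound 3 `O=S(=O)(Nc1ccc2oc(-c3ccccc3)nc2c1)c1cccc(O)c1` carries hydroxy in place of fluoro on an aromatic carbon; in this assay compound 3 also gives a limit, > 63000 nM. The steps a step that the two limits leave unreadable from compound 1 to compound 2, a step that the two limits leave unreadable from compound 1 to compound 3 and a step that the two limits leave unreadable from compound 2 to compound 3 stay unreadable because of the limit of > 63000 nM in this assay, at which 3 of the 3 values shown sit. Compound 3 thus stands at the same limit as the other two and is not placed in order against them. Compound 4 `O=S(=O)(Nc1ccc2oc(-c3ccccc3)nc2c1)c1ccc(O)cc1` differs from compound 3 by 4-hydroxyphenyl in place of 3-hydroxyphenyl on a sulfonyl sulfur. Among the measured compounds shown here, no measured step separates the two hydroxy positions, and the three measured steps give no size to go by. The step implied by the estimate is a step that the limit leaves unreadable from compound 3 to compound 4, and it is expected to show no readable change. Compound 4 is expected to give 100000 nM in this assay, within 40000 nM to 300000 nM, most likely again as a limit.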

Compound 4, half-maximal inhibitory concentration: > 63000 nM
Compound 4 gave a limit, no number; the forecaster's own chance of this, stated with the estimate: 85%; the middle value lies beyond the limit too.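

The steps from compounds 1, 2 and 3 to compound 4 cannot be read in this assay because all four compounds give the same limit: the limit of > 63000 nM in this assay, at which 4 of the 4 values shown sit.

The compounds shown leave open how these four aryl groups on the sulfonyl sulfur rank against one another.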